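Inverting the fluorinated stereocentre of compound 2

The source may hold more compounds than are shown below. What is called first, only, known or untested is meant among the compounds shown, and "the series" means these compounds.

Compound 1 `COc1ccc(F)c([C@H]2CC[C@H](COc3cccc([C@@H](CC(=O)O)C4CC4)c3)CC2)c1` and compound 2 `COc1ccc(F)c([C@H]2CC[C@H](COc3cccc([C@H](C4CC4)[C@H](F)C(=O)O)c3)CC2)c1` share one core and differ only at a saturated chain carbon bound to a carbonyl carbon and a saturated chain carbon, where compound 2 carries fluoro in place of hydrogen. In a functional assay on HEK293 cells for agonist activity at Free fatty acid receptor 1 (Homo sapiens), read by FLIPR and calcium flux (on this read-out lower numbers stand for an effect already at smaller amounts and higher numbers for an effect only at larger amounts of compound), compound 1 gives 0.94 nM. In this assay compound 2 gives 54 nM, the highest of the two numbers recorded, and its nearest neighbour is compound 1. The step of a 57-fold higher number from compound 1 to compound 2 (1.76 log units; beyond the scatter) is large and beyond the scatter.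

Compound 3 `COc1ccc(F)c([C@H]2CC[C@H](COc3cccc([C@H](C4CC4)[C@@H](F)C(=O)O)c3)CC2)c1` keeps every atom and bond of compound 2: the two compounds have the same atoms and bonds and differ only in configuration as drawn: 1 of 4 stereo elements differ; a stereocentre at a saturated chain carbon is drawn S in compound 2 and R in compound 3. Going by the values given here, no measured step changes configuration alone; the one step, a 57-fold higher number from compound 1 to compound 2 (1.76 log units; beyond the scatter), concerns the arrival of fluoro, not its orientation, so it bears only indirectly on compound 3. The number of compound 2 stands far above that of compound 1, and the other epimer at the fluorinated carbon is expected to land somewhere between those two. Compound 3 is therefore estimated at 10 nM, within a range of 2 nM to 80 nM. The expected step of a 5.4-fold lower number from compound 2 to compound 3 (0.73 log units; beyond the scatter) points toward a lower number, though with considerable uncertainty.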

Compound 3, half-maximal effective concentration: 1.1 nM
Estimate against measurement, compound 3: 9.1-fold (0.96 log units) above; the whole stated range lies above it.
By their numbers in this assay, from the lowest: compounds 1 and 3 (each within the scatter of the next); then compound 2.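

In this assay, the large penalty seen on placing fluoro at this saturated chain carbon turns out not to follow from fluoro alone, since reversing the drawn configuration at that carbon gives a 49-fold lower number from compound 2 to compound 3 (1.69 log units; beyond the scatter). With the stereocentre drawn R, the same replacement of hydrogen by fluoro gives a 1.2-fold higher number from compound 1 to compound 3 (0.07 log units; within the scatter), so compounds 1 and 3 cannot be told apart on this read-out, and only the S drawing of compound 2 stands apart from them. The large gap between the two fluorinated compounds can therefore be assigned to the configuration at this one carbon, and not to any difference in their atoms, because of the following: the fact that compounds 2 and 3 differ only in the configuration as drawn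

The compounds shown leave open whether a different group at this carbon, such as a hydroxyl, a methyl or a second fluoro, would show the same dependence on configuration. They also leave open why the S drawing raises the number so sharply, as these three compounds give the size of the effect but not its origin.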